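Methyl on the terminal phenyl of the bis-benzimidazole series

The compounds below may be only part of what the source reports. "The series", "measured", "known", "first", "only" and "open" are said of these compounds alone.

Compound 1 `N#Cc1ccc2[nH]c(-c3ccc4[nH]c(-c5ccccc5)nc4c3)nc2c1` in a functional assay on RPMI 8402 cells (Homo sapiens) for cytotoxicity (a higher number here means a weaker inhibitor, a lower number a stronger inhibitor), returns only the assay limit > 25000 nM. Compound 3 `NC(=O)c1ccc2[nH]c(-c3ccc4[nH]c(-c5ccccc5)nc4c3)nc2c1` likewise returns only the limit > 25000 nM in this assay, placing it at the limit of > 25000 nM in this assay, at which 2 of the 3 values shown sit, and leaving the step that the two limits leave unreadable from compound 1 to compound 3 without a readable size. For the measured compounds named here, compound 2 `Cc1ccccc1-c1nc2cc(-c3nc4cc(C#N)ccc4[nH]3)ccc2[nH]1` gives 1200 nM in this assay, and the step of an at least 20-fold lower number from compound 1 to compound 2 (1.31 log units; beyond the scatter) is the one sized change in the set. Compound 4 `Cc1ccccc1-c1nc2cc(-c3nc4cc(C(N)=O)ccc4[nH]3)ccc2[nH]1` differs from compound 3 by methyl in place of hydrogen on an aromatic carbon, the same change that separates compound 1 from compound 2. That single precedent is what bears on compound 4, so the expected step of an at least 8.3-fold lower number from compound 3 to compound 4 (0.92 log units; beyond the scatter) is a drop of comparable size, with its true extent left open by the starting limit. Compound 4 is therefore estimated at 3000 nM, within a range of 800 nM to 25000 nM in this assay.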

Compound 4, half-maximal inhibitory concentration: 8200 nM
For compound 4 the middle estimate is 2.7-fold (0.44 log units) below the measured one, within the range that was stated.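

The methyl in place of hydrogen now has a second case, an at least 3.0-fold lower number from compound 3 to compound 4 (0.48 log units; beyond the scatter) in this assay, so the drop seen with the nitrile also appears with the carbamoyl group. For the compounds shown here, with the methyl present, the change from cyano to carbamoyl can be sized for the first time, a 6.8-fold higher number from compound 2 to compound 4 (0.83 log units; beyond the scatter), whereas the same change without the methyl cannot be read, as both of its ends are limits. Both methyl steps run the same way, but their sizes cannot be compared: the same change on two cores in this assay, an at least 20-fold lower number (1.31 log units; beyond the scatter) from compound 1 to compound 2 and an at least 3.0-fold lower number (0.48 log units; beyond the scatter) from compound 3 to compound 4; the limit leaves it open whether they differ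

Still open, from the compounds shown here alone, is what an ethyl in place of the methyl would do in this assay. Also open, going by these compounds, is what a carboxylic acid in place of the nitrile would do.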